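This account rests on a few compounds, and the source may have more. Where it says the series, first, only, none or still open, it means among the compounds named here.

Two compounds have so far been examined in an ADME assay on microsomes from liver (Homo sapiens) for metabolic stability, read by LC-MS, with a stated time of 30 min, tested at 1 uM; on this read-out lower numbers stand for a less stable compound and higher numbers for a more stable compound. Compound 1 `Cn1c(C(=O)NCc2ccc(S(=O)(=O)c3ccccc3)cc2)cc2cnccc21` gives 78% in this assay. Compound 2 `O=C(NCc1ccc(S(=O)(=O)c2ccccc2)cc1)c1cc2ccncc2s1` gives 48% in this assay, so compound 2 stands at the lower of the two numbers, with compound 1 sitting above it by a margin beyond the usual scatter. Compound 3 `O=C(NCc1ccc(S(=O)(=O)c2ccccc2)cc1)c1ccc2nncn2c1` has not yet been measured. It differs from compound 2 on the carbonyl carbon whose other neighbour is an amide-type nitrogen: a group of 9 heavy atoms (6 carbon, 3 nitrogen; one five-membered aromatic ring with 3 hetero atoms, one six-membered aromatic ring with 1 hetero atom) in place of a group of 9 heavy atoms (7 carbon, 1 nitrogen, 1 sulfur; one five-membered aromatic ring with 1 hetero atom, one six-membered aromatic ring with 1 hetero atom), on a carbonyl carbon. Among the measured compounds shown here, no pair of measured compounds in this assay differs by an exchange of this kind, so the expectation can rest only on the two numbers at hand and on the change itself. The step of a number 14 percentage points higher from compound 2 to compound 3 (beyond the scatter) is expected to be a moderate rise in this assay, although an outcome that stays within the scatter of the value of compound 2 cannot be excluded. Compound 3 is accordingly estimated at 62% in this assay, in a range from 40% to 85%.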

Compound 3, percent of the compound remaining: 96%
Compound 3: the middle estimate sits 34 percentage points below what was measured; measured number outside the range, above it.
By their numbers in this assay, from the lowest: compound 2; then compound 1; then compound 3.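

In this assay the exchange on the carbonyl carbon whose other neighbour is an amide-type nitrogen brings a number 48 percentage points higher from compound 2 to compound 3 (beyond the scatter) and so shows that the read-out responds strongly to the group at this place. The large step comes without any change in group size or ring sizes, since both groups hold 9 heavy atoms in one five-membered and one six-membered aromatic ring; what differs is the make-up of the group, with 3 hetero atoms in the five-membered ring instead of 1, and 3 hydrogen-bond acceptors instead of 2. No measurement at hand explains the rise.

Among the compounds shown here, the single step changes the atoms of both rings and the way they are joined, so it cannot say which of these features matters for the read-out. Also open, on these data alone, is whether the high value of compound 3 would persist with a simpler pyridine ring on the carbonyl carbon, or with a methyl group or a chlorine atom added to the group that entered.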